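This account rests on a few compounds, and the source may have more. Where it says the series, first, only, none or still open, it means among the compounds named here.

Measured so far in a functional assay on HGC-27 cells (Homo sapiens) for inhibition, read by MTT assay, with a stated time of 72 h; on this read-out higher numbers stand for weaker inhibition and lower numbers for stronger inhibition:

compound 1 `Cc1cc(N2CC[C@@H](C)[C@@H](N(C)c3ncnc4[nH]ccc34)C2)n2nc(SCCc3ccccc3)nc2n1` gives 11800 nM
compound 2 `CCc1cc(N2CC[C@@H](C)[C@@H](N(C)c3ncnc4[nH]ccc34)C2)n2ncnc2n1` gives only a limit, > 100000 nM

Among the measured compounds shown here, compound 1 is the only compound with a number in this assay; the other value shown sits at the limit of > 100000 nM in this assay, at which 1 of the 2 values shown sits. For the measured compounds named here, compound 2 carries no sulfur substituent on its core and its result is a limit of the assay, not a number, so the pair gives no measured step to work from.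

Compound 3 `C#CSc1nc2nc(C)cc(N3CC[C@@H](C)[C@@H](N(C)c4ncnc5[nH]ccc45)C3)n2n1` differs from compound 1 by ethynyl in place of phenethyl on a sulfur. Going by the values given here, the measured set holds no step of this kind. Compound 1 already sits at 11800 nM. Among the compounds with values here, since the only other value in this assay is a limit, the expectation for a smaller substituent on the sulfur is a step toward weaker inhibition, a 3.0-fold higher number from compound 1 to compound 3 (0.47 log units; beyond the scatter), with a real chance that only a limit is reported. Compound 3 is therefore estimated at 35000 nM in this assay, expected range 8000 nM to 100000 nM.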

Compound 3, half-maximal inhibitory concentration: 35100 nM
For compound 3 the middle estimate is 1.0-fold (0.00 log units) below the measured one; the measured number falls inside the stated range.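

In this assay, the sulfur substituent now has its first measured step: ethynyl in place of phenethyl gives a 3.0-fold higher number from compound 1 to compound 3 (0.47 log units; beyond the scatter). The step is modest, and compound 3 still gives a number, 35100 nM, so a measurable value at this position does not depend on the six-membered aromatic ring of phenethyl. Compound 2 differs from compound 1 in more than one place, and its result is only a limit: the limit of > 100000 nM in this assay, at which 1 of the 3 values shown sits.

This single step cannot separate the loss of the aromatic ring from the shortening of the chain or the entry of the triple bond. On these data alone, how a plain methyl, a longer phenylpropyl chain or a phenethyl carrying a terminal amine or carboxylic acid on this sulfur would compare remains open.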